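This account rests on a few compounds, and the source may have more. Where it says the series, first, only, none or still open, it means among the compounds named here.

Of the compounds shown here, three built on one shared core have been measured in a functional assay on A549 cells (Homo sapiens) for inhibition, read by MTT assay, with a stated time of 72 h; a lower number here means a stronger inhibitor, a higher number a weaker inhibitor. Compound 1 `O=C(Nc1ccc(Oc2ccnc3[nH]ccc23)cc1)c1cn(-c2ccc(Br)cc2F)c2ccccc2c1=O` gives 1330 nM. Compound 2 `COc1ccc(-n2cc(C(=O)Nc3ccc(Oc4ccnc5[nH]ccc45)cc3)c(=O)c3ccccc32)cc1` gives 4980 nM. Compound 3 `Cn1ccc2c(Oc3ccc(NC(=O)c4cn(-c5ccc(Br)cc5)c5ccccc5c4=O)cc3F)ccnc21` gives 1390 nM. Among these three numbers compound 3 has the second highest; compound 1 sits within the scatter of it, so the two cannot be told apart, while compound 2 lies beyond the scatter with a clearly higher number, that is, a weaker inhibitor.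

Compound 4 `COc1ccc(-n2cc(C(=O)Nc3ccc(Oc4ccnc5c4ccn5C)c(F)c3)c(=O)c3ccccc32)cc1` has not yet been measured. It differs from compound 3 in one place: methoxy in place of bromo on an aromatic carbon. Among the measured compounds shown here, the one measured step that bears on this is a 3.7-fold higher number from compound 1 to compound 2 (0.57 log units; beyond the scatter), where a methoxyphenyl likewise took the place of a halogenated phenyl on the aromatic nitrogen and the number rose modestly. A step of a similar size and the same direction is therefore expected here. Compound 4 is expected to give 4200 nM in this assay, with a likely range from 1800 nM to 10000 nM. The expected change from compound 3 to compound 4 is a 3.0-fold higher number from compound 3 to compound 4 (0.48 log units; beyond the scatter), which would make compound 4 a somewhat weaker inhibitor than compound 3.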

Compound 4, half-maximal inhibitory concentration: 3210 nM
For compound 4 the middle estimate is 1.3-fold (0.12 log units) above the measured one; low and high end bracket the measured number.
By their numbers in this assay, from the lowest: compounds 1 and 3 (each within the scatter of the next); then compounds 4 and 2 (each within the scatter of the next).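

In this assay, replacing bromo with methoxy on the ring carried by the aromatic nitrogen gives a 2.3-fold higher number from compound 3 to compound 4 (0.36 log units; beyond the scatter), so this single exchange, at the place para to a large group, yields a weaker inhibitor. The earlier step, a 3.7-fold higher number from compound 1 to compound 2 (0.57 log units; beyond the scatter), pointed the same way, but there the ring lost a fluoro as well, so the exchange of bromo for methoxy could not be read on its own; the new pair isolates that exchange and shows the same direction on a differently substituted version of the shared core, which makes two pairs in agreement and none against them. Nothing measured here explains why the number rises with this exchange.

Going by these compounds, it stays open whether the loss of bromo or the arrival of methoxy accounts for the step, and a plain hydrogen or a chloro at this place would help separate the two. On these data alone, how the number would respond to an amine, a carboxylic acid or a longer chain such as ethoxy at the same place also remains unknown.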